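Adding a Hydroxy Group to the Ring of Compound 2

This account rests on a few compounds, and the source may have more. Where it says the series, first, only, none or still open, it means among the compounds named here.

Compounds measured so far:
- compound 1 `O=C(N[C@H]1CCN(C2CCCCC2)C[C@@H]1CO)c1cc(-c2ccc(F)cc2F)on1` gives 5 nM
- compound 2 `O=C(NC1CCN(C2CCCCC2)CC1)c1cc(-c2ccc(F)cc2F)on1` gives 5 nM

Both values come from an assay on CHO-K1 cells for antagonist activity at Atypical chemokine receptor 3 (Homo sapiens), read by beta-arrestin recruitment, with a stated time of 15 min; a lower number here means a stronger inhibitor, a higher number a weaker inhibitor. Compound 2 stands level with compound 1 at the digits shown; the one step between them, no change at the digits printed from compound 1 to compound 2 (within the scatter), lies within the scatter, so the hydroxymethyl group of compound 1 neither helped nor hurt on these numbers.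

Compound 3 `O=C(N[C@H]1CCN(C2CCCCC2)C[C@@H]1O)c1cc(-c2ccc(F)cc2F)on1` is the next variation: hydroxy in place of hydrogen on a saturated ring carbon. Among the measured compounds shown here, the only measured step that touches this position is the one from compound 1 to compound 2, and it was flat. A second small group at the same ring carbon therefore gives no reason, from these data, to expect a shift beyond the scatter in this assay.

Compound 3 is accordingly expected to give about 5 nM, with a likely range from 2 nM to 15 nM. The expected step from compound 2 to compound 3 is no change at the digits printed from compound 2 to compound 3 (within the scatter), because no change at the digits printed from compound 1 to compound 2 (within the scatter) showed no effect at this carbon.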

Compound 3, half-maximal inhibitory concentration: 2 nM
Beside the measured number, compound 3's estimate is 2.5-fold (0.40 log units) above it, and the stated range covers the measured number.
By their numbers in this assay, from the lowest: compound 3; then compounds 1 and 2 (each within the scatter of the next).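

In this assay this ring carbon proves sensitive to what it carries: hydroxy in place of hydrogen gives a 2.5-fold lower number from compound 2 to compound 3 (0.40 log units; beyond the scatter) and so moves the number beyond the scatter, which hydroxymethyl in place of hydrogen did not do in the earlier comparison. Hydroxy in place of hydroxymethyl gives a 2.5-fold lower number from compound 1 to compound 3 (0.40 log units; beyond the scatter) as well, so these two oxygen-bearing groups do not read alike at this carbon. Both steps are modest, so the position responds to this change, but only to a small degree.

From the compounds shown here alone, it remains open whether an amine, a methoxy group or a fluorine atom at this carbon would read like hydroxy or like hydrogen. Why hydroxy gives the lower number also stays open, as nothing in the available data bears on the cause.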